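The source may report more compounds than this note shows. Statements on the series, on what has been measured and on what is new or still open speak of the compounds shown alone.

In an ADME assay on microsomes from liver (Homo sapiens) for metabolic stability, read by LC-MS, with NADPH named in the record, with a stated time of 60 min, tested at 1 uM, in the absence of a further agent (on this read-out higher numbers stand for a more stable compound and lower numbers for a less stable compound), compound 1 `COc1ccc(-c2c(C)nc3c(N4CC[C@@H](NC(=O)OCc5ccccc5)C4)cc(C)nn23)cc1OC` gives the limit > 95% and no number. Compound 2 `COc1ccc(-c2c(C)nc3c(N4CC[C@@H](NS(=O)(=O)C5CC5)C4)cc(C)nn23)cc1OC` likewise gives the limit > 95% and no number. Compound 3 `COc1ccc(-c2c(C)nc3c(N4CC[C@@H](NS(=O)(=O)c5ccc(C)cc5)C4)cc(C)nn23)cc1OC` also gives the limit > 95% and no number. Compound 3 therefore stands at the limit of > 95% in this assay, at which 3 of the 3 values shown sit. Compound 4 `COc1ccc(-c2c(C)nc3c(N4CC[C@@H](NS(=O)(=O)c5cccs5)C4)cc(C)nn23)cc1OC` carries thiophen-2-yl in place of 4-methylphenyl on a sulfonyl sulfur. The closest measured change is a step that the two limits leave unreadable from compound 2 to compound 3, and the other two are a step that the two limits leave unreadable from compound 1 to compound 3 and a step that the two limits leave unreadable from compound 1 to compound 2. None of these has a readable size, so in this assay no step beyond the scatter is expected in either direction. The expected step is a number no higher from compound 3 to compound 4 (the limit leaves the size open). The expected value for compound 4 is 95% within an estimated range of 82% to 100%.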

Compound 4, percent of the compound remaining: > 95%
Compound 4 ended at the assay's limit; the forecaster's own chance of this, stated with the estimate: 60%; the middle value sits exactly at the limit.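

In this assay compound 4 gives the limit > 95%, so its steps from compound 1, compound 2 and compound 3 cannot be read. The compounds shown leave open how their groups on the amine nitrogen rank in stability, because all share one limit: the limit of > 95% in this assay, at which 4 of the 4 values shown sit.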